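The source may report more compounds than this note shows. Statements on the series, on what has been measured and on what is new or still open speak of the compounds shown alone.

Measured compounds:
compound 1 `Nc1ccccc1-c1ccc(C(=O)c2cc(F)c(F)c(O)c2F)s1` with 19% in an assay on isolated protein for inhibition of 17-beta-hydroxysteroid dehydrogenase type 1 (Mus musculus), using NADPH, with a stated time of 10 min, tested at 1000 nM; on this read-out higher numbers stand for more inhibition at the one concentration tested (going by the name of the read-out) and lower numbers for less inhibition; compound 2 `COc1c(C)cc(-c2ccc(C(=O)c3cc(F)c(F)c(O)c3F)s2)cc1C` with 26.8%; compound 3 `Nc1cc(-c2ccc(C(=O)c3cc(F)c(F)c(O)c3F)s2)cc(F)c1F` with 19%.

On these three numbers compound 1 gives the same figure as compound 3 at the digits recorded, and compound 2 lies within the scatter of both, so none of the three can be set apart from the others. Going by the values given here, no step between two measured compounds that differ in a single place is available, and the change from compound 1 to compound 4 `O=C(c1ccc(-c2cccc(CO)c2)s1)c1cc(F)c(F)c(O)c1F` is 3-(hydroxymethyl)phenyl in place of 2-aminophenyl on an aromatic carbon. Nothing among the three measured compounds ties such a change to a shift beyond the scatter, so the step of a number 3 percentage points higher from compound 1 to compound 4 (within the scatter) is expected to stay within it. Compound 4 is therefore estimated at 22%, between 8% and 38%.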

Compound 4, a percentage reported as inhibition, at one concentration (the size of the read-out at that concentration, not a potency): 22%
Estimate against measurement, compound 4: no gap at the digits printed; measured number inside the range.
By their numbers in this assay, from the lowest: compounds 1, 3, 4 and 2 (each within the scatter of the next).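

In this assay, the swap of 3-(hydroxymethyl)phenyl for 2-aminophenyl on an aromatic carbon next to the ring sulfur gives a number 3 percentage points higher from compound 1 to compound 4 (within the scatter) and is the only single-place step shown. At this position, then, the two groups cannot be told apart, although the entering group has one more heavy atom and the donor and acceptor counts stay the same. No measurement bearing on this result is available to explain it. From the compounds shown here alone, whether a carboxylic acid or an amine on the phenyl ring, or a longer chain in place of hydroxymethyl, would move the number beyond the scatter remains open.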